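Swapping allyloxy for isopropyl on the thioester carbonyl

The source may hold more compounds than are shown below. What is called first, only, known or untested is meant among the compounds shown, and "the series" means these compounds.

Compound 1 `C=CCOC(=O)SCCCCCCNC(=O)c1cc(-c2ccncc2)n[nH]1` gives 32900 nM in a functional assay on HCT-116 cells (Homo sapiens) for inhibition, read by MTT assay, with a stated time of 96 h; a lower number here means a stronger inhibitor of growth, a higher number a weaker inhibitor of growth.
Compound 2 `O=C(NCCCCCCS)c1cc(C2CCCCC2)n[nH]1` reaches only a limit, > 50000 nM.
Compound 3 `Cc1cc(C(=O)NCCCCCCS)[nH]n1` also reaches only a limit, > 50000 nM.

Within the data shown here, compound 1 is thus the only compound with a real number; the two other values sit at the limit of > 50000 nM in this assay, at which 2 of the 3 values shown sit. Among the measured compounds shown here, the single measured step, a step that the two limits leave unreadable from compound 2 to compound 3, runs between two limits and so gives no readable size. Compound 4 `CC(C)C(=O)SCCCCCCNC(=O)c1cc(-c2ccncc2)n[nH]1` differs from compound 1 by isopropyl in place of allyloxy on a carbonyl carbon. For the measured compounds named here, no measured step touches this part of the molecule, so nothing in the data points to a change in either direction beyond the scatter. Compound 4 is therefore expected to give about 30000 nM in this assay, somewhere between 10000 nM and 80000 nM, which would mean an expected step of a 1.1-fold lower number from compound 1 to compound 4 (0.04 log units; within the scatter).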

Compound 4, concentration for 50% growth inhibition: 22700 nM
The estimate for compound 4 lay 1.3-fold (0.12 log units) above the measured number; measured number inside the range.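

Among these compounds, on a carbonyl carbon whose other neighbours are sulfur, this swap gives the first readable step in this assay, a 1.4-fold lower number from compound 1 to compound 4 (0.16 log units; within the scatter). The number therefore stays within the scatter when allyloxy, with its oxygen and double bond, gives way to isopropyl, so this one change does not separate the two compounds. No measurement shown accounts for this result.

As far as these compounds go, whether any group at this place moves the number remains open. An amine or a longer chain on the same carbonyl carbon would test that.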